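Adding a chloro group to compound 3

The compounds below may be only part of what the source reports. "The series", "measured", "known", "first", "only" and "open" are said of these compounds alone.

compound 1 `O=C(CCCCC(S)CCS)Nc1ccccc1Cl` gives 8.19%
compound 2 `O=C(CCCCC(S)CCS)Nc1ccc(F)cc1` gives 6.84%
compound 3 `CC(=O)SCCC(CCCCC(=O)Nc1ccccc1)SC(C)=O` gives 13.1%

Compound 3 gives 13.1% in a functional assay on NCI-H460 cells (Homo sapiens) for inhibition, read by MTT assay, with a stated time of 24 h, tested at 1 ug/mL (a lower number here means less inhibition of growth, a higher number more inhibition of growth at the concentration tested), and lies within the scatter of both compound 1 and compound 2, so the three values cannot be put in order. Compound 4 `CC(=O)SCCC(CCCCC(=O)Nc1cccc(Cl)c1)SC(C)=O` follows from compound 3 by a single change chloro in place of hydrogen on an aromatic carbon that turns phenyl into 3-chlorophenyl. Among the measured compounds shown here, no two measured compounds differ in one place only, so no measured step shows the size of such a change. Compound 1 also carries a chloro group, and compound 1 gives 8.19% within the scatter of compound 3, though the two differ in more than that group. No step beyond the scatter is therefore expected in this assay in either direction, and only a slight rise is anticipated. The estimated change is a number 0.9 percentage points higher from compound 3 to compound 4 (within the scatter) in this reading. Compound 4 is estimated at 14% with an expected range of 6% to 26% in this assay when it is measured.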

Compound 4, percent growth inhibition at one concentration: 0.31%
Beside the measured number, compound 4's estimate is 13.7 percentage points above it; the measured number lies below the stated range.
By their numbers in this assay, from the lowest: compounds 4, 2, 1 and 3 (each within the scatter of the next, the first and the last beyond it).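

In this assay, among the compounds shown here, chloro in place of hydrogen on an aromatic carbon, meta to a large group, turns phenyl into 3-chlorophenyl and gives a number 12.8 percentage points lower from compound 3 to compound 4 (beyond the scatter), the only measured change in one place and one that lies beyond the scatter. The earlier compounds shown here could not show that this position matters, but here a single added heavy atom removes nearly all the growth inhibition seen with compound 3 at the concentration tested. Nothing measured here accounts for this step.

Going by these compounds, whether another group at this position, such as a methyl, a methoxy or an amine, would give a similar fall remains open. So does whether chloro at this position would act the same way in a compound with free thiol groups in place of the acetylated sulfurs.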